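A few compounds are considered here, and "the series" means these few. Any claim that something is new, unique, unknown or untested is made for them only; others in the source may bear on it.

In a functional assay on MCF7 cells (Homo sapiens) for cytotoxicity, read by MTT assay, with a stated time of 24 h (on this read-out higher numbers stand for weaker inhibition and lower numbers for stronger inhibition), compound 1 `O=c1nc2ccc(Br)cn2cc1Cc1ccc(Br)cc1` gives 97200 nM as its half-maximal inhibitory concentration. Compound 2 `Nc1cccn2cc(Cc3ccc(F)cc3)c(=O)nc12` gives 135000 nM in the same test, and these two numbers lie within the usual scatter of each other, so compound 1 and compound 2 cannot be told apart here. The reading for compound 3 `Cc1ccc(Cc2cn3cc(Cl)ccc3nc2=O)cc1` is > 1000000 nM which is a limit of the assay and not a number.

The next compound to be tested, compound 4 `O=c1nc2ccc(Br)cn2cc1Cc1ccccc1`, keeps the core of compound 1 but has hydrogen in place of bromo on an aromatic carbon. Within the data shown here, no measured pair shows this change alone, so the expectation in this assay rests on thin ground. It points to a modest step toward weaker inhibition, perhaps not far beyond the scatter. Compound 3, which carries no bromo group, stands at the limit > 1000000 nM and this suggests that direction. Compound 2 also carries no bromo group and goes against the suggestion with 135000 nM as its value. The estimate therefore means an expected 2.1-fold higher number from compound 1 to compound 4 (0.31 log units; beyond the scatter) and no more than that. In this assay compound 4 is expected to give about 200000 nM (estimated range 70000 nM to 700000 nM).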

Compound 4, half-maximal inhibitory concentration: > 1000000 nM
Compound 4: no number, only a limit; the forecaster's own chance of this, stated with the estimate: 25%; middle value at least 5.0-fold (0.69 log units) from the limit.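

Among these compounds, this is the first pair in this assay that differs in one place only, so the bromo group on the six-membered aromatic ring of carbon only can now be judged on its own: hydrogen in its place gives an at least 10-fold higher number from compound 1 to compound 4 (1.01 log units; beyond the scatter). The other bromo group and the rest of the core of compound 1 stay the same, so within this pair the whole step goes with the loss of that one heavy atom. The size of the step is a minimum and not an exact figure, since compound 4 stands at a limit of the assay, a limit that also holds another of the compounds shown: the limit of > 1000000 nM in this assay, at which 2 of the 4 values shown sit.

Going by these compounds, what remains open is whether bromo itself matters at this position, or whether another group there, such as methoxy or an amine, would serve as well. Compound 2 carries a fluoro group on that ring and compound 3 a methyl group, but both also differ from compound 1 elsewhere, so neither can answer this.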